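This account rests on a few compounds, and the source may have more. Where it says the series, first, only, none or still open, it means among the compounds named here.

Measured in a functional assay on T29Kt1 cells (Homo sapiens) for cytotoxicity, read by sulforhodamine B assay, with a stated time of 3 days; on this read-out lower numbers stand for stronger inhibition and higher numbers for weaker inhibition:
Compound 1 `O=Cc1cn(Cc2ccc(Br)c(Br)c2)c2ccccc12`: 630 nM
Compound 2 `OCc1cn(Cc2cccc(Br)c2)c2ccccc12`: 32 nM
Compound 3 `OCc1cn(Cc2ccc(Br)cc2)c2ccccc12`: 390 nM

Compound 3, at 390 nM, lies within the scatter of compound 1 and clearly higher than compound 2. Compound 4 `OCc1cn(Cc2ccc(Br)c(Br)c2)c2ccccc12` follows from compound 3 by one change bromo in place of hydrogen on an aromatic carbon. Its new bromo group sits where compound 2 carries its only one, and compound 2 reaches 32 nM. Within the data shown here, a lower number is therefore expected, though no measured pair shows what a second bromo group does. The expected 3.5-fold lower number from compound 3 to compound 4 (0.55 log units; beyond the scatter) is a moderate drop in this assay. The estimate for compound 4 is 110 nM, with an expected range of 25 nM to 450 nM.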

Compound 4, half-maximal inhibitory concentration: 100 nM
The estimate for compound 4 lay 1.1-fold (0.04 log units) above the measured number; the range from low to high includes it.
By their numbers in this assay, from the lowest: compound 2; then compound 4; then compounds 3 and 1 (each within the scatter of the next).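

In this assay, bromo in place of hydrogen on an aromatic carbon, ortho to a bromo group, gives a 3.9-fold lower number from compound 3 to compound 4 (0.59 log units; beyond the scatter) while the same kind of change at the other bromo position gives a 3.1-fold higher number from compound 2 to compound 4 (0.49 log units; beyond the scatter) and so the direction of this change depends on where it is made. Among these compounds, with both bromo groups in place, hydroxymethyl in place of formyl gives a 6.3-fold lower number from compound 1 to compound 4 (0.80 log units; beyond the scatter) and this is the first step to show that change. No measurement offered here explains either effect. Still open, on these data alone, is whether chloro or methoxy would behave like bromo at this position. Also open, as far as these compounds go, is how an amine or a carboxylic acid would compare with the hydroxymethyl group.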